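The source may hold more compounds than are shown below. What is called first, only, known or untested is meant among the compounds shown, and "the series" means these compounds.

Compound 1 `Cn1c(C2CC2)nc2ccc(-n3ccc(OCc4ccc(Cl)cc4)cc3=O)cc21` and compound 2 `CCn1c(C2CC2)nc2ccc(-n3ccc(OCc4ccc(Cl)cc4)cc3=O)cc21` share one core and differ only by methyl in place of hydrogen on a saturated chain carbon bound to an aromatic nitrogen. In an assay on CHO cells for displacement of a labelled ligand from melanin-concentrating hormone receptor 1 (Homo sapiens), read by scintillation counting, with a stated time of 1 h (a lower number here means a stronger inhibitor, a higher number a weaker inhibitor), compound 1 gives 35 nM, and compound 2 gives 37 nM; the step of a 1.1-fold higher number from compound 1 to compound 2 (0.02 log units; within the scatter) leaves the two numbers within the scatter of each other. Compound 3 `Cn1c(C2CC2)nc2ccc(-n3ccc(OCc4cccc(Cl)c4)cc3=O)cc21` differs from compound 1 by 3-chlorophenyl in place of 4-chlorophenyl on a saturated chain carbon bound to an oxygen on an aromatic ring. Among the measured compounds shown here, no measured step touches that position, so the only guide is the flat step already seen. Compound 3 is therefore expected at 60 nM, between 15 nM and 250 nM, a step of a 1.7-fold higher number from compound 1 to compound 3 (0.23 log units; within the scatter) that is expected to stay within the scatter, with wide uncertainty.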

Compound 3, half-maximal inhibitory concentration: 100 nM
For compound 3 the middle estimate is 1.7-fold (0.22 log units) below the measured one, and the stated range covers the measured number.
By their numbers in this assay, from the lowest: compounds 1 and 2 (each within the scatter of the next); then compound 3.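

Unlike the methyl step on the chain at the aromatic nitrogen, the exchange of 4-chlorophenyl for 3-chlorophenyl in this assay gives a 2.9-fold higher number from compound 1 to compound 3 (0.46 log units; beyond the scatter) and so shows a change that can be read. The two compounds carry the same atoms joined differently, so this position responds to where the chlorine stands on the phenyl ring, with the 4-chlorophenyl of compound 1 giving the lower number. No measurement shown here offers an explanation for this step.

The compounds shown leave open how 2-chlorophenyl or a plain phenyl would fare at this position. They also leave open whether a pyridine ring could take the place of the chlorophenyl.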